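The source may report more compounds than this note shows. Statements on the series, on what has been measured and on what is new or still open speak of the compounds shown alone.

Measured in an assay on cells with melanin-concentrating hormone receptor 1 (Homo sapiens) as the target, read by radioligand binding; on this read-out higher numbers stand for weaker inhibition and lower numbers for stronger inhibition:
compound 1 `CCCOc1cccc2ccc(N)nc12` gives 1100 nM
compound 2 `Nc1ccc2cccc(OCCC3CC3)c2n1` gives 492 nM
compound 3 `CC(C)=CCOc1cccc2ccc(N)nc12` gives > 2000 nM, a limit of the assay and not a number.

Compound 3 thus sits at the upper edge of the values shown, with the two measured steps that end there reading an at least 1.8-fold higher number from compound 1 to compound 3 (0.25 log units; that floor lies within the scatter) and an at least 4.0-fold higher number from compound 2 to compound 3 (0.60 log units; beyond the scatter). Compound 4 `Nc1ccc2cccc(OCC3CCCO3)c2n1` differs from compound 3 as oxolan-2-yl in place of 2-methylprop-1-en-1-yl on a saturated chain carbon bound to an oxygen on an aromatic ring. Among the measured compounds shown here, the steps that bear on this change run the other way: ethyl in compound 1 and cyclopropylmethyl in compound 2 both lie below the limit, and a 2.2-fold lower number from compound 1 to compound 2 (0.35 log units; beyond the scatter) favours the ring-bearing chain end. Putting the oxolan-2-yl ring in place of 2-methylprop-1-en-1-yl is therefore expected to bring compound 4 back into the measured range, a step estimated at an at least 2.8-fold lower number from compound 3 to compound 4 (0.45 log units; beyond the scatter) in this assay. Compound 4 is estimated at 700 nM, within 300 nM to 2000 nM.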

Compound 4, half-maximal inhibitory concentration: > 2000 nM
Compound 4: no number, only a limit; the forecaster's own chance of this, stated with the estimate: 20%; at least 2.8-fold (0.45 log units) between middle value and limit.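

Replacing cyclopropylmethyl with oxolan-2-yl gives an at least 4.0-fold higher number from compound 2 to compound 4 (0.60 log units; beyond the scatter), so a ring at the chain end does not by itself keep the value in the measured range. Against ethyl, the same ring gives an at least 1.8-fold higher number from compound 1 to compound 4 (0.25 log units; that floor lies within the scatter), and that floor alone shows no separation. Compound 3 and compound 4 both rest at a limit of the assay, so the step between them cannot be read: the limit of > 2000 nM in this assay, at which 2 of the 4 values shown sit.

From the compounds shown here alone, how far either compound lies past that limit stays open. Also open, going by these compounds, is whether a cyclopentyl ring in place of oxolan-2-yl, or an amine at the chain end, would return a measurable value.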